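Trimming a Methyl from the Ring of Compound 2

The compounds below may be only part of what the source reports. "The series", "measured", "known", "first", "only" and "open" are said of these compounds alone.

In a functional assay on MCF7 cells (Homo sapiens) for inhibition, read by MTT assay (a lower number here means a stronger inhibitor, a higher number a weaker inhibitor), compound 2 `Cc1ccc(-c2nnc(NC(=O)CCCCCCC(=O)NO)s2)s1` gives 880 nM. Compound 1 `O=C(CCCCCCC(=O)Nc1nnc(-c2ccco2)s1)NO` gives 880 nM, the same at the digits shown, so the two stand together at the lowest of the three numbers. Compound 3 `O=C(CCCN1CCN(C(=O)Nc2cccc3ncccc23)CC1)NO` gives 7190 nM, a gap from compound 2 that lies beyond the scatter. Compound 4 `O=C(CCCCCCC(=O)Nc1nnc(-c2cccs2)s1)NO` differs from compound 2 by hydrogen in place of methyl on an aromatic carbon. Among the compounds with values here, only one measured step touches this ring: the swap of the whole aromatic ring, furan-2-yl for 5-methylthiophen-2-yl, gave no change at the digits printed from compound 1 to compound 2 (within the scatter). Compound 4 is therefore expected to stay close to compound 2, because even the larger ring swap no change at the digits printed from compound 1 to compound 2 (within the scatter) moved nothing beyond the scatter. For compound 4 the estimate is 900 nM, within 450 nM to 1800 nM. The expected step is a 1.0-fold higher number from compound 2 to compound 4 (0.01 log units; within the scatter).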

Compound 4, half-maximal inhibitory concentration: 880 nM
Estimate against measurement, compound 4: 1.0-fold (0.01 log units) above, and the stated range covers the measured number.
By their numbers in this assay, from the lowest: compounds 1, 2 and 4 (each within the scatter of the next); then compound 3.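

Taking off the methyl next to the ring sulfur gives no change at the digits printed from compound 2 to compound 4 (within the scatter) in this assay, so this one carbon can go without a measurable shift. The earlier ring swap changed the ring and the methyl together, whereas thiophen-2-yl in place of furan-2-yl, with no methyl on either ring, gives no change at the digits printed from compound 1 to compound 4 (within the scatter) and so tests the ring alone. No measured evidence explains why either change leaves the number in place.

Still open, as far as these compounds go, is whether an amine, a carboxylic acid or a longer chain on this same ring carbon would also leave the number in this assay unchanged.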